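The source may report more compounds than this note shows. Statements on the series, on what has been measured and on what is new or still open speak of the compounds shown alone.

In a functional assay on MV4-11 cells (Homo sapiens) for antiproliferative activity, read by luminescence, with a stated time of 72 h (a higher number here means a weaker inhibitor, a lower number a stronger inhibitor), compound 1 `C=CS(=O)(=O)NC/C=C/c1cc(OC)cc(O)c1C(=O)OC(C)C` gives 4660 nM and compound 2 `C=CS(=O)(=O)NC/C=C/c1cc(OC)cc(O)c1C(=O)OCC(C)c1ccccc1` gives 7730 nM, so these two values lie within the scatter of each other. Compound 3 `COc1cc(O)c(C(=O)OCC(C)c2ccccc2)c(/C=C/CN2C(=O)C=CC2=O)c1` differs from compound 2 as follows: a group of 7 heavy atoms (4 carbon, 1 nitrogen, 2 oxygen; one five-membered non-aromatic ring with 1 hetero atom) in place of a group of 6 heavy atoms (2 carbon, 1 nitrogen, 2 oxygen, 1 sulfur; no ring), on a saturated chain carbon bound to a double-bonded chain carbon. Within the data shown here, the only measured step, a 1.7-fold higher number from compound 1 to compound 2 (0.22 log units; within the scatter), changes a different group and does not cover this replacement of (vinylsulfonyl)amino. The data therefore support no expected step beyond the scatter in this assay, and no direction can be argued. The estimated step is a 1.5-fold lower number from compound 2 to compound 3 (0.19 log units; within the scatter). For compound 3 the expected value is 5000 nM, with an estimated range of 1200 nM to 15000 nM.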

Compound 3, half-maximal inhibitory concentration: 3380 nM
Estimate against measurement, compound 3: 1.5-fold (0.17 log units) above; measured number inside the range.
By their numbers in this assay, from the lowest: compounds 3, 1 and 2 (each within the scatter of the next, the first and the last beyond it).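

At the saturated chain carbon bound to a double-bonded chain carbon, the five-membered non-aromatic ring group in place of (vinylsulfonyl)amino gives in this assay a 2.3-fold lower number from compound 2 to compound 3 (0.36 log units; beyond the scatter). This modest step shows that a change at this position can move the number beyond the scatter, which 2-phenylpropyl in place of isopropyl did not do. No measurement available here explains the step. Open, as far as these compounds go, is how an acetamide or a primary amine at this position would compare with both groups. Also open, from the compounds shown here alone, is whether the step holds with isopropyl in place of 2-phenylpropyl.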